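Swapping the sulfanyl amino ester for a pyrrolidine ester

The source may report more compounds than this note shows. Statements on the series, on what has been measured and on what is new or still open speak of the compounds shown alone.

Values measured in a functional assay on MCF7 cells (Homo sapiens) for inhibition, read by MTT assay, with a stated time of 3 days (on this read-out higher numbers stand for weaker inhibition and lower numbers for stronger inhibition), are as follows

Compound 1 `CC[C@H](C)[C@H](NCC(=O)NNC(=O)COc1ccc(-c2nc3ccccc3s2)cc1OC)C(=O)O` gives 1710 nM
Compound 2 `COc1cc(-c2nc3ccccc3s2)ccc1OCC(=O)NNC(=O)CN[C@@H](CS)C(=O)O` gives 1230 nM
Compound 3 `CCOC(=O)[C@H](CS)NCC(=O)NNC(=O)COc1ccc(-c2nc3ccccc3s2)cc1OC` gives 2880 nM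

Compound 3 (2880 nM) lies within the scatter of compound 1 but not of compound 2. The modest gap to the latter is a 2.3-fold higher number from compound 2 to compound 3 (0.37 log units; beyond the scatter) and comes with ethyl in place of hydrogen on an oxygen next to a carbonyl group.

Compound 4 `CCOC(=O)[C@@H]1CCCN1CC(=O)NNC(=O)COc1ccc(-c2nc3ccccc3s2)cc1OC` has not yet been measured. Its difference from compound 3 is 2-(ethoxycarbonyl)pyrrolidin-1-yl in place of (1-(ethoxycarbonyl)-2-sulfanylethyl)amino on a saturated chain carbon bound to a carbonyl carbon and the change sits on a saturated chain carbon bound to a carbonyl carbon. The ethoxycarbonyl group remains, so the modest step from ethyl on that oxygen is not repeated here. The nearest evidence is a 1.4-fold lower number from compound 1 to compound 2 (0.14 log units; within the scatter) for a swap of sec-butyl to sulfanylmethyl, and a 1.7-fold higher number from compound 1 to compound 3 (0.23 log units; within the scatter) for a larger change on the amine nitrogen. Both stayed within the scatter. For the measured compounds named here, no measured compound carries the pyrrolidine ring, so this evidence is indirect.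

The expected change is a 1.2-fold lower number from compound 3 to compound 4 (0.06 log units; within the scatter) and no shift beyond the scatter is anticipated. The estimate for compound 4 is 2500 nM with an expected range of 1000 nM to 6000 nM on this evidence.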

Compound 4, half-maximal inhibitory concentration: 770 nM
Compound 4: the middle estimate sits 3.2-fold (0.51 log units) above what was measured; measured number below the stated range.
By their numbers in this assay, from the lowest: compounds 4, 2, 1 and 3 (each within the scatter of the next, the first and the last beyond it).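

On a saturated chain carbon bound to a carbonyl carbon, this assay now shows that this position can respond beyond the scatter: 2-(ethoxycarbonyl)pyrrolidin-1-yl in place of (1-(ethoxycarbonyl)-2-sulfanylethyl)amino gives a 3.7-fold lower number from compound 3 to compound 4 (0.57 log units; beyond the scatter) with the ethoxycarbonyl group present on both sides. The pyrrolidine also separates from the isoleucine-like (1-carboxy-2-methylbutyl)amino group, with a 2.2-fold lower number from compound 1 to compound 4 (0.35 log units; beyond the scatter) as the step, whereas the step to the pyrrolidine from (1-carboxy-2-sulfanylethyl)amino is a 1.6-fold lower number from compound 2 to compound 4 (0.20 log units; within the scatter) and so leaves those two compounds level, which means that an ethyl ester at this position need not give the higher number seen for compound 3. No measurement offered here accounts for any of these steps.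

The change removes the sulfanyl group and the amine hydrogen and closes the ring all at once, so the compounds shown cannot say which of these matters. An open-chain tertiary amine, a piperidine ring, or a pyrrolidine bearing a free carboxylic acid in place of the ethoxycarbonyl group would begin to pull these apart.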